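The source may hold more compounds than are shown below. What is called first, only, known or untested is meant among the compounds shown, and "the series" means these compounds.

The series keeps one core and varies the substituent on the amide-type nitrogen. Compound 1 `N#Cc1ccccc1NC(=O)c1[nH]cnc1-c1nc2ccccc2[nH]1` carries a 2-cyanophenyl there; in a functional assay on MDA-MB-231 cells (Homo sapiens) for inhibition, read by MTT assay, with a stated time of 48 h (a lower number here means a stronger inhibitor, a higher number a weaker inhibitor), compound 1 gives 34200 nM. Compound 2 `CC(C)(C)NC(=O)c1[nH]cnc1-c1nc2ccccc2[nH]1` carries a tert-butyl. For compound 2 this assay reports only a limit, > 40000 nM, and no number (the limit of > 40000 nM in this assay, at which 1 of the 3 values shown sits). Compound 3 `O=C(NC1CCCC1)c1[nH]cnc1-c1nc2ccccc2[nH]1` carries a cyclopentyl, and in this assay compound 3 gives 20600 nM. Among the two numbers shown, compound 3 holds the lower one, but the step of a 1.7-fold lower number from compound 1 to compound 3 (0.22 log units; within the scatter) is within the scatter, so compound 1 and compound 3 are not separated by the data. The other steps, an at least 1.1-fold higher number from compound 1 to compound 2 (0.06 log units; that floor lies within the scatter) and an at least 1.9-fold lower number from compound 2 to compound 3 (0.28 log units; that floor lies within the scatter), rest on a limit and are floors only; both also lie within the scatter.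

Compound 4 `O=C(NC1CCCCC1)c1[nH]cnc1-c1nc2ccccc2[nH]1` differs from compound 3 by cyclohexyl in place of cyclopentyl on an amide-type nitrogen. Within the data shown here, none of the measured steps changes the size of a saturated ring; the three steps above exchange an aryl, a branched alkyl and a cyclopentyl against one another, and none of them moves beyond the scatter. For compound 4 the expected step of a 1.1-fold lower number from compound 3 to compound 4 (0.06 log units; within the scatter) is therefore none beyond the scatter. The estimate for compound 4 in this assay is 18000 nM, expected to fall between 8000 nM and 40000 nM.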

Compound 4, half-maximal inhibitory concentration: 8300 nM
The estimate for compound 4 lay 2.2-fold (0.34 log units) above the measured number, and the stated range covers the measured number.
By their numbers in this assay, from the lowest: compound 4; then compounds 3 and 1 (each within the scatter of the next). At a limit, above all of these: compound 2.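

In this assay, among these compounds, going from a five-membered to a six-membered non-aromatic carbon ring on the amide-type nitrogen gives a 2.5-fold lower number from compound 3 to compound 4 (0.39 log units; beyond the scatter) and is the first step to pass the scatter, whereas the exchanges among 2-cyanophenyl, tert-butyl and cyclopentyl separated nothing. Cyclohexyl also stands clear of the aryl group, with a 4.1-fold lower number from compound 1 to compound 4 (0.61 log units; beyond the scatter) as the step, which leaves compound 4 as the most potent of the four compounds shown. Against tert-butyl the reading is an at least 4.8-fold lower number from compound 2 to compound 4 (0.68 log units; beyond the scatter) and only a floor, as compound 2 is held by a limit: the limit of > 40000 nM in this assay, at which 1 of the 4 values shown sits.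

Among the compounds shown here, with only two saturated ring sizes in hand, the result marks a difference between cyclopentyl and cyclohexyl and not a trend with ring size, so it remains open whether a cycloheptyl would extend the step or reverse it. Also open, as far as these compounds go, is whether the step depends on an all-carbon ring, which a tetrahydropyranyl or a piperidinyl in place of cyclohexyl would test.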